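Adding a dimethylamino group to the chain of compound 2

A few compounds are considered here, and "the series" means these few. Any claim that something is new, unique, unknown or untested is made for them only; others in the source may bear on it.

Measured in a functional assay on A549 cells (Homo sapiens) for cytotoxicity, read by sulforhodamine B assay; on this read-out lower numbers stand for stronger inhibition and higher numbers for weaker inhibition:
- Compound 1 `O=C1c2cccc3c2c(cc2c4ccccc4sc32)C(=O)N1CN1CCNCC1`: 11800 nM
- Compound 2 `CCCCN1C(=O)c2cccc3c2c(cc2c4ccccc4sc32)C1=O`: 1350 nM

Of these two compounds, compound 2 has the lower number, 1350 nM, and the gap between them lies beyond the scatter. The next compound, compound 3 `CN(C)CCCN1C(=O)c2cccc3c2c(cc2c4ccccc4sc32)C1=O`, has not yet been measured in this assay. It differs from compound 2 as follows: dimethylamino in place of methyl on a saturated chain carbon, three bonds along the chain from an amide-type nitrogen in a ring. In short, dimethylamino stands in place of methyl on a saturated chain carbon, three bonds along the chain from an amide-type nitrogen in a ring.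

Going by the values given here, only one measured step bears on this change: an 8.7-fold lower number from compound 1 to compound 2 (0.94 log units; beyond the scatter). There, propyl replaced piperazin-1-yl on a saturated chain carbon bound to an amide-type nitrogen in a ring. Read in reverse, that step hints at a higher number when a nitrogen-bearing group is present on the chain. However, the group and its place are different in compound 3, so the hint is weak, and a clear shift in either direction is not expected. The expected outcome is a 1.4-fold lower number from compound 2 to compound 3 (0.13 log units; within the scatter). For compound 3 the estimate is 1000 nM, with an expected range of 180 nM to 5500 nM.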

Compound 3, half-maximal inhibitory concentration: 250 nM
For compound 3 the middle estimate is 4.0-fold (0.60 log units) above the measured one; measured number inside the range.
By their numbers in this assay, from the lowest: compound 3; then compound 2; then compound 1.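

In this assay, dimethylamino on the saturated chain carbon, three bonds along the chain from an amide-type nitrogen in a ring, gives a 5.4-fold lower number from compound 2 to compound 3 (0.73 log units; beyond the scatter), which shows that a nitrogen-bearing group on this chain can go with a lower number and not only a higher one. Compound 1 had suggested the opposite, yet a 47-fold lower number from compound 1 to compound 3 (1.67 log units; beyond the scatter) is larger than an 8.7-fold lower number from compound 1 to compound 2 (0.94 log units; beyond the scatter), so the all-carbon butyl chain of compound 2 is not the side chain with the lowest number among the three, and the chain tolerates a terminal amine at this place. The outcome therefore depends on which nitrogen-bearing group is present and where it sits on the chain, though no data shown here explain why the number falls.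

Compound 1 and compound 3 differ in both the amine and the length of the chain, so the two effects cannot be separated. The compounds shown leave open whether a shorter or longer chain ending in dimethylamino would keep this gain, and whether another terminal group, such as diethylamino, morpholine or a hydroxyl group, would do the same.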